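Thiophene for Phenyl at the Fast End of Microsomal Stability

The source may hold more compounds than are shown below. What is called first, only, known or untested is meant among the compounds shown, and "the series" means these compounds.

Measured compounds:
compound 1 `COc1cc(C(=O)N(C/C=C/c2ccccc2)Cc2ccc(CC(=O)O)cc2)cc(OC)c1C` — > 3.33 h
compound 2 `COc1cc([C@@H](O)[C@@H](CCCc2ccccc2)Cn2ccc(CC(=O)O)c2)cc(OC)c1C` — < 0.25 h

In an ADME assay on microsomes (Rattus norvegicus) for metabolic stability, using NADPH (a higher number here means that the compound lasts longer, a lower number that the compound disappears faster), compound 1 gives > 3.33 h, which is a limit of the assay rather than a number (the limit of > 3.33 h in this assay, at which 1 of the 2 values shown sits). Compound 2 gives < 0.25 h in this assay, again only a limit (the limit of < 0.25 h in this assay, at which 1 of the 2 values shown sits). For the measured compounds named here, compound 2 therefore stands at the fast end of the two values shown, while compound 1 stands at the other end; no step between measured compounds is known, so neither value is tied to a structural change.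

Compound 3 `COc1cc([C@@H](O)[C@@H](CCCc2ccsc2)Cn2ccc(CC(=O)O)c2)cc(OC)c1C` differs from compound 2 by thiophen-3-yl in place of phenyl on a saturated chain carbon, five bonds along the chain from an aromatic carbon, an aromatic nitrogen and an oxygen on a saturated carbon, thiophen-3-yl in place of phenyl on a saturated chain carbon. Going by the values given here, with no measured step to lean on, no shift beyond the usual scatter is expected in this assay. Compound 3 is estimated at 0.2 h (range 0.08 h to 0.6 h), an expected step that the limit leaves unreadable from compound 2 to compound 3.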

Compound 3, half-life: < 0.25 h
Compound 3 gave a limit, no number (the forecaster's own chance of this, stated with the estimate: 65%); the middle value does not contradict the limit.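

Compound 2 and compound 3 both give only a limit in this assay, so no step between them can be read: the limit of < 0.25 h in this assay, at which 2 of the 3 values shown sit.

The compounds shown leave open how short either half-life really is, and whether thiophen-3-yl in place of phenyl changes it at all.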